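The source may hold more compounds than are shown below. What is called first, only, known or untested is meant among the compounds shown, and "the series" means these compounds.

The study concerns three measured compounds and one not yet measured, all tested in an ADME assay on PBMC cells (Homo sapiens) for cytotoxicity, read by MTT assay; a higher number here means a weaker inhibitor, a lower number a stronger inhibitor. Compound 1 `O=C(N/N=C/N1CCN(c2cc3c(cc2F)c(=O)c(C(=O)O)cn3C2CC2)CC1)c1cccc(C(F)(F)F)c1` gives in this assay > 322000 nM, which is a limit of the assay rather than a number. Compound 2 `O=C(N/N=C/N1CCN(c2cc3c(cc2F)c(=O)c(C(=O)O)cn3C2CC2)CC1)c1cccc(F)c1` gives in this assay > 305000 nM, likewise a limit and not a number. Among the measured compounds shown here, compound 3 `CCn1cc(C(=O)O)c(=O)c2cc(F)c(N3CCN(/C=N/NC(=O)c4ccc(C(F)(F)F)cc4)CC3)cc21` gives in this assay 262000 nM, the only number among the three values shown. From compound 1 to compound 2 the change is fluoro in place of trifluoromethyl on an aromatic carbon, and the step it made is a step that the two limits leave unreadable from compound 1 to compound 2. This is because compound 1 sits at the limit of > 322000 nM in this assay, at which 1 of the 3 values shown sits. It is also because compound 2 sits at the limit of > 305000 nM in this assay, at which 1 of the 3 values shown sits.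

Compound 4 `CCn1cc(C(=O)O)c(=O)c2cc(F)c(N3CCN(/C=N/NC(=O)c4ccc(F)cc4)CC3)cc21` has not yet been measured in this assay. It differs from compound 3 by fluoro in place of trifluoromethyl on an aromatic carbon, the same kind of change as that from compound 1 to compound 2, though the place is not the same: in compound 1 the group sits meta to a large group, in compound 3 para to a large group. How the core of compound 3 differs from the core of compound 1 is not broken down here. The step from compound 1 to compound 2 gives no readable size, so the expectation for compound 4 rests on compound 3 alone, which stands at 262000 nM. Compound 4 is expected to give about 280000 nM in this assay, estimated between 150000 nM and 500000 nM. That estimate means an expected step of a 1.1-fold higher number from compound 3 to compound 4 (0.03 log units; within the scatter).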

Compound 4, half-maximal inhibitory concentration: > 331000 nM
Compound 4 ended at the assay's limit (the forecaster's own chance of this, stated with the estimate: 40%); middle value at least 1.1-fold (0.07 log units) from the limit.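

In this assay, fluoro in place of trifluoromethyl on the core of compound 3 gave an at least 1.2-fold higher number from compound 3 to compound 4 (0.10 log units; that floor lies within the scatter), so no drop in the number appears on this core. That step is only a floor because compound 4 sits at a limit of the assay and not at a number: the limit of > 331000 nM in this assay, at which 1 of the 4 values shown sits. On the core of compound 1 the same kind of change, at a different place on the ring, cannot be read, as both of its ends are limits, so the compounds do not show whether the change has the same size on the two cores, and they show no rise beyond the scatter on either.

The compounds shown leave open how the change reads when the group sits at the same place on the ring on both cores, and how far the number of the fluoro compound on the core of compound 3 really lies from that of compound 3. They also leave open what a chloro, a methoxy or an amine on the same aromatic carbon would give in this assay.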